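From 4-methoxyphenoxy to 3,4-dimethoxyphenoxy in compound 3

The source may report more compounds than this note shows. Statements on the series, on what has been measured and on what is new or still open speak of the compounds shown alone.

In a functional assay on CCRF-CEM cells (Homo sapiens) for antiproliferative activity, read by cell counting, with a stated time of 96 h (on this read-out lower numbers stand for stronger inhibition and higher numbers for weaker inhibition), compound 2 (`COc1ccc(Oc2ccccc2NC(C)=C2C(=O)CC(c3ccccc3)CC2=O)cc1`) gives 120 nM. Among the measured compounds shown here, its only measured neighbour, compound 1 (`CC(Nc1ccccc1Oc1cccc(F)c1)=C1C(=O)CC(c2ccccc2)CC1=O`), gives 170 nM, so the two stand level within the scatter. Compound 3 (`COc1ccc(Oc2ccccc2NC(C)=C2C(=O)CC(c3ccccc3)CC2=O)cc1OC`) carries one further change, methoxy in place of hydrogen on an aromatic carbon, ortho to a methoxy group and meta to a large group, which turns 4-methoxyphenoxy into 3,4-dimethoxyphenoxy. For the measured compounds named here, one measured step bears on it, a 1.4-fold lower number from compound 1 to compound 2 (0.15 log units; within the scatter), with 4-methoxyphenyl in place of 3-fluorophenyl on an oxygen on an aromatic ring. Going by the values given here, that step stayed within the scatter, and no measured pair shows the addition of a methoxy group, so no step beyond the scatter is expected in this assay. The expected step is a 1.1-fold higher number from compound 2 to compound 3 (0.03 log units; within the scatter). Compound 3 is estimated at 130 nM, with an expected range of 50 nM to 350 nM.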

Compound 3, half-maximal inhibitory concentration: 160 nM
Beside the measured number, compound 3's estimate is 1.2-fold (0.09 log units) below it, and the stated range covers the measured number.
By their numbers in this assay, from the lowest: compounds 2, 3 and 1 (each within the scatter of the next).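

The first measured addition of a methoxy group on this ring, ortho to a methoxy group and meta to a large group, leaves the numbers level in this assay (a 1.3-fold higher number from compound 2 to compound 3 (0.12 log units; within the scatter)). The change of the whole group on the oxygen, 3,4-dimethoxyphenyl in place of 3-fluorophenyl, also stays within the scatter (a 1.1-fold lower number from compound 1 to compound 3 (0.03 log units; within the scatter)), so among compounds 1, 2 and 3 neither step separates one group from another. Nothing available explains why these numbers stand level.

The compounds shown leave open whether a group of another kind on this ring, such as an amine, a carboxylic acid or a longer chain, would give a step beyond the scatter. They also leave open what a change elsewhere on the shared core would do, since all three carry it unchanged.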